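Hydroxybutyl chain to benzyl on the amine

The compounds below may be only part of what the source reports. "The series", "measured", "known", "first", "only" and "open" are said of these compounds alone.

Compound 2 `OCCCCNc1ncc(-c2cccc(Cl)c2)c(-c2ccccc2)n1` carries the hydroxyalkyl chain. On these data alone, in an assay on CHO cells for displacement of a labelled ligand from adenosine receptor A1 (Homo sapiens), read by scintillation counting, with a stated time of 1 h, tested at 1 uM (on this read-out lower numbers stand for less inhibition and higher numbers for more inhibition at the one concentration tested (going by the name of the read-out)), compound 2 reaches only a limit of the assay, > 80%, so its exact level is unknown (the limit of > 80% in this assay, at which 1 of the 2 values shown sits). Among the measured compounds shown here, compound 1 `CC(C)Nc1ncc(-c2cccc(Cl)c2)c(-c2ccccc2)n1` gives 71% in this assay, and the step of a number at least 9 percentage points higher from compound 1 to compound 2 (that floor lies within the scatter) is the single measured comparison. Compound 3 `Clc1cccc(-c2cnc(NCc3ccccc3)nc2-c2ccccc2)c1` differs from compound 2 by phenyl in place of 3-hydroxypropyl on a saturated chain carbon bound to a nitrogen on an aromatic ring. That measured step concerns another exchange on the same nitrogen, so it bears only loosely on this one. Compound 3 is expected to move by a number at least 15 percentage points lower from compound 2 to compound 3 (beyond the scatter) from the limit. Compound 3 is estimated at 65%, within a range from 40% to 85%.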

Compound 3, a percentage reported as inhibition, at one concentration (the size of the read-out at that concentration, not a potency): 16%
Compound 3: the middle estimate sits 49 percentage points above what was measured, and the stated range ends above it.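

In this assay, benzyl on this nitrogen gives a number at least 64 percentage points lower from compound 2 to compound 3 (beyond the scatter), and against the isopropyl compound it gives a number 55 percentage points lower from compound 1 to compound 3 (beyond the scatter). The earlier step between the two open chains had a floor within the scatter, so only now does this position show a large change, and it does so against both chains. Compound 2 stands at a limit of the assay: the limit of > 80% in this assay, at which 1 of the 3 values shown sits.

On these data alone, what a cyclohexylmethyl group or a longer phenylethyl chain on the same nitrogen would give stays open. So does whether the drop belongs to the aromatic ring itself.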